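Replacing the ring group of compound 2

A few compounds are considered here, and "the series" means these few. Any claim that something is new, unique, unknown or untested is made for them only; others in the source may bear on it.

In a functional assay on A549 cells (Homo sapiens) for antiproliferative activity, read by MTT assay (a lower number here means a stronger inhibitor, a higher number a weaker inhibitor), compound 1 `Cn1c(=O)c(=O)n(C2CCCC2)c2nc(N/N=C/c3ccc(F)c(Cl)c3)ncc21` gives 9410 nM and compound 2 `Cn1c(=O)c(=O)n(C2CCCC2)c2nc(N/N=C/c3ccc(C(F)(F)F)cc3)ncc21` gives 40600 nM. Compound 2 therefore holds the higher of the two numbers, which makes it the weaker inhibitor of this pair. Compound 3 `Cc1cc(C)c(/C=N/Nc2ncc3c(n2)n(C2CCCC2)c(=O)c(=O)n3C)c(C)c1` keeps the shared core and alters one group: 2,4,6-trimethylphenyl in place of 4-(trifluoromethyl)phenyl on a carbon with a double bond to nitrogen. Put simply, 2,4,6-trimethylphenyl replaces 4-(trifluoromethyl)phenyl on a carbon with a double bond to nitrogen. Within the data shown here, only one measured step changes this same place: a 4.3-fold higher number from compound 1 to compound 2 (0.63 log units; beyond the scatter). It is modest but beyond the scatter, so this assay does respond to a swap here. A single step cannot show which way a new group will move the number, and no ring carrying 2,4,6-trimethylphenyl has been measured yet. With compound 2 at 40600 nM, the higher of the two values, a modest step toward a lower number is expected, although the direction remains uncertain. The estimated step is a 2.0-fold lower number from compound 2 to compound 3 (0.31 log units; beyond the scatter). For compound 3 the expected value is 20000 nM, within an estimated range from 7000 nM to 60000 nM.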

Compound 3, half-maximal inhibitory concentration: 12000 nM
Compound 3: middle estimate off by 1.7-fold (0.22 log units), on the high side; the measured number falls inside the stated range.
By their numbers in this assay, from the lowest: compounds 1 and 3 (each within the scatter of the next); then compound 2.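

In this assay, among these compounds, the change of ring gives a 3.4-fold lower number from compound 2 to compound 3 (0.53 log units; beyond the scatter), so a swap at this place can lower the number as well as raise it, which the single earlier step could not show. The other new comparison gives a 1.3-fold higher number from compound 1 to compound 3 (0.11 log units; within the scatter), so 2,4,6-trimethylphenyl and 3-chloro-4-fluorophenyl cannot be told apart here, even though the first is built only of carbon and the second carries chlorine and fluorine, and among these three compounds only the 4-(trifluoromethyl)phenyl of compound 2 stands apart. Fluorine on the ring therefore does not track with one outcome, since compound 1 and compound 2 both carry it yet differ beyond the scatter, and no measurement offered here explains why these rings rank as they do.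

Still open, as far as these compounds go, is how a plain phenyl ring, or a ring bearing an amine or a carboxylic acid, would behave on this carbon with a double bond to nitrogen. Also open, from the compounds shown here alone, is whether any group at this place can bring the number clearly below those of compound 1 and compound 3.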